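The compounds below may be only part of what the source reports. "The series", "measured", "known", "first", "only" and "open" are said of these compounds alone.

Compound 1 `CC1CCN(C2CCN(S(=O)(=O)c3nccn3C)CC2)CC1`: > 5000 nM
Compound 2 `COc1cccc(S(=O)(=O)N2CCC(N3CCC(C)CC3)CC2)c1`: > 5000 nM

In a functional assay on DLD-1 cells (Homo sapiens) for antiproliferative activity, read by CellTiter-Glo, with a stated time of 72 h (on this read-out higher numbers stand for weaker inhibition and lower numbers for stronger inhibition), compound 1 gives > 5000 nM, which is a limit of the assay and not a number. Compound 2 gives > 5000 nM, also a limit. Among the measured compounds shown here, the one measured step, a step that the two limits leave unreadable from compound 1 to compound 2, therefore cannot be read, since both values sit at the limit of > 5000 nM in this assay, at which 2 of the 2 values shown sit. Compound 3 `CC1CCN(C2CCN(S(=O)(=O)c3cc(Cl)cc(Cl)c3)CC2)CC1` differs from compound 2 by 3,5-dichlorophenyl in place of 3-methoxyphenyl on a sulfonyl sulfur. For the measured compounds named here, no measured step bears on this change, so no direction can be drawn from the data. Compound 3 is estimated at 6000 nM, with a range from 800 nM to 30000 nM. The expected step is a step that the limit leaves unreadable from compound 2 to compound 3.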

Compound 3, half-maximal inhibitory concentration: 3400 nM
The estimate for compound 3 lay 1.8-fold (0.25 log units) above the measured number; measured number inside the range.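

Among the compounds shown here, on the sulfonyl sulfur, 3,5-dichlorophenyl gives the only true number so far in this assay, rather than a limit. Replacing 3-methoxyphenyl gives an at least 1.4-fold lower number from compound 2 to compound 3 (0.16 log units; that floor lies within the scatter) and replacing 1-methyl-1H-imidazol-2-yl gives an at least 1.4-fold lower number from compound 1 to compound 3 (0.16 log units; that floor lies within the scatter) on the same shared core. Both sizes remain floors, since the reference compounds are not read as numbers: the limit of > 5000 nM in this assay, at which 2 of the 3 values shown sit.

As far as these compounds go, whether chlorine itself matters stays open. So does how a phenyl ring carrying bromine, trifluoromethyl or an amine would read at this place.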